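A few compounds are considered here, and "the series" means these few. Any claim that something is new, unique, unknown or untested is made for them only; others in the source may bear on it.

Compound 1 `COc1cccc(/C=N/Nc2ncc3c(n2)n(C2CCCC2)c(=O)c(=O)n3C)c1`: 45800 nM
Compound 2 `Cn1c(=O)c(=O)n(C2CCCC2)c2nc(N/N=C/c3cccc(Cl)c3Cl)ncc21`: 26400 nM
Compound 3 `Cn1c(=O)c(=O)n(C2CCCC2)c2nc(N/N=C/c3cc(C(F)(F)F)cc(C(F)(F)F)c3)ncc21`: 4360 nM

In a functional assay on HCT-116 cells (Homo sapiens) for antiproliferative activity, read by MTT assay (on this read-out higher numbers stand for weaker inhibition and lower numbers for stronger inhibition), compound 2 gives 26400 nM, the second highest of the three numbers. Its nearest neighbour is compound 1, which gives 45800 nM, and the step between them, a 1.7-fold lower number from compound 1 to compound 2 (0.24 log units; within the scatter), is within the scatter. Within the data shown here, the furthest is compound 3, which gives 4360 nM; no single-change step links it to compound 2, so the two values are simply noted side by side.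

Compound 4 `CSc1ccc(/C=N/Nc2ncc3c(n2)n(C2CCCC2)c(=O)c(=O)n3C)cc1` is not yet measured. It differs from compound 2 in one place: 4-(methylsulfanyl)phenyl in place of 2,3-dichlorophenyl on a carbon with a double bond to nitrogen. Among the measured compounds shown here, the one measured step that bears on this kind of exchange, one aryl ring traded for another on the carbon with a double bond to nitrogen, is a 1.7-fold lower number from compound 1 to compound 2 (0.24 log units; within the scatter), and it stayed within the scatter. On that basis the step of a 1.1-fold lower number from compound 2 to compound 4 (0.02 log units; within the scatter) is expected to stay within the scatter as well, with no clear direction. Compound 4 is therefore estimated at 25000 nM, with a range from 8000 nM to 80000 nM.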

Compound 4, half-maximal inhibitory concentration: 9010 nM
The estimate for compound 4 lay 2.8-fold (0.44 log units) above the measured number; the measured number falls inside the stated range.
By their numbers in this assay, from the lowest: compound 3; then compound 4; then compounds 2 and 1 (each within the scatter of the next).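

In this assay the exchange of one aryl ring for another on the carbon with a double bond to nitrogen can move the number beyond the scatter, as a 2.9-fold lower number from compound 2 to compound 4 (0.47 log units; beyond the scatter) shows, whereas the earlier step between compound 1 and compound 2 stayed within it. The same holds against the 3-methoxyphenyl group, with a 5.1-fold lower number from compound 1 to compound 4 (0.71 log units; beyond the scatter), so this position responds to the choice of ring, although both steps are modest and the two rings that leave and enter in the first step have the same heavy-atom count. Nothing available explains the difference. The compounds shown leave open whether the sulfur or the place of the substituent on the ring carries the step, which 4-methoxyphenyl could separate. They also leave open how a longer chain such as ethylsulfanyl, or an amine on that ring, would read.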